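From dimethylamino to methoxy on the aromatic ring

The source may hold more compounds than are shown below. What is called first, only, known or untested is meant among the compounds shown, and "the series" means these compounds.

In a functional assay on CHP-134 cells (Homo sapiens) for antiproliferative activity, with a stated time of 72 h (a higher number here means a weaker inhibitor, a lower number a stronger inhibitor), compound 3 `CN(C)c1ccc(C(=O)N(CCC(=O)NCc2ccccc2)Cc2ccc(C(=O)NO)cc2)cc1` gives 1160 nM and compound 1 `Cc1cc(C)cc(C(=O)N(CCC(=O)NCc2ccccc2)Cc2ccc(C(=O)NO)cc2)c1` gives 2030 nM. These two cannot be told apart, since a 1.8-fold lower number from compound 1 to compound 3 (0.24 log units; within the scatter) stays within the usual scatter. Compound 2 `COc1cc(OC)cc(C(=O)N(CCC(=O)NCc2ccccc2)Cc2ccc(C(=O)NO)cc2)c1` stands well apart at 12300 nM.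

Compound 4 `COc1ccc(C(=O)N(CCC(=O)NCc2ccccc2)Cc2ccc(C(=O)NO)cc2)cc1` has methoxy in place of dimethylamino on an aromatic carbon, para to a large group (methoxy in place of dimethylamino on an aromatic carbon). For the measured compounds named here, no measured step makes this exact change. The nearest evidence comes from swaps of the group on the carbonyl carbon, which gave a 6.1-fold higher number from compound 1 to compound 2 (0.78 log units; beyond the scatter) and an 11-fold lower number from compound 2 to compound 3 (1.03 log units; beyond the scatter). Only compound 2 carries methoxy groups, as 3,5-dimethoxyphenyl, and its 12300 nM suggests that methoxy may lead to a higher number. That is one compound with a different pattern, so only a modest move in that direction is expected, not the full size of those steps. The estimated step is a 2.1-fold higher number from compound 3 to compound 4 (0.32 log units; beyond the scatter). For compound 4 the estimated value is 2400 nM, with an expected range of 900 nM to 7000 nM.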

Compound 4, half-maximal inhibitory concentration: 1900 nM
For compound 4 the middle estimate is 1.3-fold (0.10 log units) above the measured one; measured number inside the range.
By their numbers in this assay, from the lowest: compounds 3, 4 and 1 (each within the scatter of the next); then compound 2.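

In this assay, the swap on an aromatic carbon, para to a large group, gives a 1.6-fold higher number from compound 3 to compound 4 (0.21 log units; within the scatter), so dimethylamino and methoxy cannot be told apart in this place. Methoxy alone therefore does not bring the high number seen for compound 2: the change from 3,5-dimethoxyphenyl to 4-methoxyphenyl gives a 6.5-fold lower number from compound 2 to compound 4 (0.81 log units; beyond the scatter). The 4-methoxyphenyl and 3,5-dimethylphenyl groups also remain indistinguishable, with a 1.1-fold lower number from compound 1 to compound 4 (0.03 log units; within the scatter).

No measurement shown here explains why the 3,5-dimethoxyphenyl compound stands apart from the other three. From the compounds shown here alone, it also remains open whether a carboxylic acid or a primary amine, para to the same large group, would stay within the scatter of methoxy and dimethylamino or would move the number clearly.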